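The source may hold more compounds than are shown below. What is called first, only, known or untested is meant among the compounds shown, and "the series" means these compounds.

Measured in an assay on cell membranes from brain for binding affinity to Adrenergic receptor alpha-1 (Rattus norvegicus), read by radioligand binding (a lower number here means a stronger inhibitor, a higher number a weaker inhibitor), so far:
compound 1, `COc1ccccc1N1CCN(CCn2nc(-n3cnc4ccccc43)ccc2=O)CC1`, 33 nM
compound 2, `COc1ccccc1N1CCN(CCCn2nc(-n3cnc4ccccc43)ccc2=O)CC1`, 6.5 nM
compound 3, `COc1ccccc1N1CCN(CCn2nc(-n3ccc4ccccc43)ccc2=O)CC1`, 22.7 nM

Compound 2 gives the lowest of these three numbers, and its gaps to compound 1 and compound 3 both lie beyond the usual scatter. The difference between the core of compound 1 and the core of compound 2 is not broken down here. Compound 3 differs from compound 1 by 1H-indol-1-yl in place of 1H-benzimidazol-1-yl on an aromatic carbon, and that change gave a 1.5-fold lower number from compound 1 to compound 3 (0.16 log units; within the scatter) in this assay.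

Compound 4, `COc1ccccc1N1CCN(CCCn2nc(-n3ccc4ccccc43)ccc2=O)CC1`, has not yet been measured. It differs from compound 2 by 1H-indol-1-yl in place of 1H-benzimidazol-1-yl on an aromatic carbon, the same change as between compound 1 and compound 3, at the same place. Resting on that earlier step from compound 1 to compound 3, a 1.5-fold lower number from compound 1 to compound 3 (0.16 log units; within the scatter), compound 4 is expected to stay close to compound 2, with an estimated step of a 1.3-fold lower number from compound 2 to compound 4 (0.11 log units; within the scatter). In this assay compound 4 is therefore estimated at 5 nM, likely between 2 nM and 12 nM.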

Compound 4, inhibition constant: 3.2 nM
For compound 4 the middle estimate is 1.6-fold (0.19 log units) above the measured one, within the range that was stated.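

In this assay, 1H-indol-1-yl in place of 1H-benzimidazol-1-yl again moved the number in the same direction, with a 2.0-fold lower number from compound 2 to compound 4 (0.31 log units; beyond the scatter). Within this series, the change carried from one core to the other with no difference that can be told from the scatter: the same change on two cores in this assay, a 1.5-fold lower number (0.16 log units; within the scatter) from compound 1 to compound 3 and a 2.0-fold lower number (0.31 log units; beyond the scatter) from compound 2 to compound 4, 1.4-fold (0.15 log units) apart, within the scatter of two such steps. Within the data shown here, these are only two pairs, one of them within the scatter on its own, so they do not show that the change would behave alike on other cores, and they do not explain the result.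

The compounds shown leave open what an amine or a nitrile would give on that same aromatic carbon. They also leave open whether the step would hold on a core with a longer chain than that of compound 4.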